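Changing the Amine-Bearing Chain of Compound 3

The source may report more compounds than this note shows. Statements on the series, on what has been measured and on what is new or still open speak of the compounds shown alone.

Compound 3 `CCN(CC)CCn1cnnc1-c1cc(Oc2ccc(NC(=O)Nc3ccc(F)c(Cl)c3)cc2F)ccn1` is measured in a functional assay on MDA-MB-231 cells (Homo sapiens) for antiproliferative activity, read by MTT assay, with a stated time of 72 h (a lower number here means a stronger inhibitor, a higher number a weaker inhibitor), where compound 3 gives 34000 nM. Among the three measured compounds this is the second highest number: compound 2 `CCN(CC)CCn1cnnc1-c1cc(Oc2ccc(NC(=O)Nc3ccc(F)c(F)c3)cc2F)ccn1` gives 41300 nM, and a 1.2-fold lower number from compound 2 to compound 3 (0.08 log units; within the scatter); compound 1 `CCN(CC)CCn1cnnc1-c1cc(Oc2ccc(NC(=O)Nc3cccc(C(F)(F)F)c3)cc2F)ccn1` gives 720 nM, and a 47-fold higher number from compound 1 to compound 3 (1.67 log units; beyond the scatter). Compound 4 `CN(C)CCCn1cnnc1-c1cc(Oc2ccc(NC(=O)Nc3ccc(F)c(Cl)c3)cc2F)ccn1` differs from compound 3 only in the chain carrying the amine: (dimethylamino)methyl in place of diethylamino on a saturated chain carbon, two bonds along the chain from an aromatic nitrogen. Every measured step, including a 57-fold higher number from compound 1 to compound 2 (1.76 log units; beyond the scatter), changes the aryl group on the amide-type nitrogen, while the amine-bearing chain is the same in compounds 1, 2 and 3. Among the measured compounds shown here, no measured step therefore bears on this change, and no step beyond the scatter is expected, so compound 4 is expected at no change at the digits printed from compound 3 to compound 4 (within the scatter). Compound 4 is estimated at 34000 nM, with a range from 11000 nM to 100000 nM.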

Compound 4, half-maximal inhibitory concentration: 14200 nM
Compound 4: middle estimate off by 2.4-fold (0.38 log units), on the high side, within the range that was stated.
By their numbers in this assay, from the lowest: compound 1; then compound 4; then compounds 3 and 2 (each within the scatter of the next).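

Replacing 2-(diethylamino)ethyl with 3-(dimethylamino)propyl gives a 2.4-fold lower number from compound 3 to compound 4 (0.38 log units; beyond the scatter) in this assay, so the amine-bearing chain can shift this read-out. That step is much smaller than the aryl change a 47-fold higher number from compound 1 to compound 3 (1.67 log units; beyond the scatter). No measurement shown explains the shift.

From the compounds shown here alone, both the chain length and the groups on the amine differ here, so their separate contributions stay unknown; a 2-(dimethylamino)ethyl chain would separate them. Going by these compounds, how a morpholine on the chain would read, or whether this chain change carries over to the 3-(trifluoromethyl)phenyl series, also stays open.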